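From isopropoxy to 3-(4-methylpiperazin-1-yl)propoxy on compound 2

This account rests on a few compounds, and the source may have more. Where it says the series, first, only, none or still open, it means among the compounds named here.

Of the compounds shown here, three have numbers so far in a toxicity assay on Huh-7.5 cells (Homo sapiens) for inhibition, read by MTT assay, with a stated time of 96 h; a lower number here means that less compound is tolerated, a higher number that more compound is tolerated. Compound 1 (`CN(C)C1CCN(Cc2ccc(NC(=O)c3ccc(OCCCCl)c([N+](=O)[O-])c3)cc2C(F)(F)F)C1`) gives a half-maximal cytotoxic concentration of 5800 nM here. Compound 2 (`CCC(=O)Nc1cc(C(=O)Nc2ccc(OC)cc2)ccc1OC(C)C`) gives 113000 nM and lies within the scatter of compound 3 (`CCC(=O)Nc1cc(C(=O)Nc2ccc(N(C)C)cc2)ccc1OC`), which gives 171000 nM in the same read-out. Compound 1 stands apart from both, with a lower number beyond the scatter.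

Compound 4 (`CCC(=O)Nc1cc(C(=O)Nc2ccc(OC)cc2)ccc1OCCCN1CCN(C)CC1`) carries 3-(4-methylpiperazin-1-yl)propyl in place of the isopropyl of compound 2, on an oxygen on an aromatic ring (3-(4-methylpiperazin-1-yl)propyl in place of isopropyl on an oxygen on an aromatic ring). For the measured compounds named here, no two measured compounds differ in one place, so this change has no direct precedent. Going by the values given here, the only guide is compound 1 (5800 nM), the one measured compound with a non-aromatic ring, and it differs from compound 2 in much else. A step of a 3.2-fold lower number from compound 2 to compound 4 (0.51 log units; beyond the scatter) is therefore expected in this assay, toward a lower number and beyond the scatter, with low confidence. For compound 4 the estimated value is 35000 nM (range 10000 nM to 100000 nM).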

Compound 4, half-maximal cytotoxic concentration: 127000 nM
Compound 4: middle estimate off by 3.6-fold (0.56 log units), on the low side; measured number outside the range, above it.
By their numbers in this assay, from the lowest: compound 1; then compounds 2, 4 and 3 (each within the scatter of the next).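

In this assay the isopropyl of compound 2 can be replaced by 3-(4-methylpiperazin-1-yl)propyl on an oxygen on an aromatic ring with no step beyond the scatter (a 1.1-fold higher number from compound 2 to compound 4 (0.05 log units; within the scatter)). This first one-place comparison in the series shows that, on this core, the oxygen can carry a chain with one six-membered non-aromatic ring and 2 hydrogen-bond acceptors while compound 2 and compound 4 remain within the scatter of each other. No measurement on hand offers an explanation for this result.

On these data alone, whether other groups on this oxygen, such as a carboxylic acid or a shorter chain ending in dimethylamino, would also stay within the scatter remains open. Also open, as far as these compounds go, is whether 3-(4-methylpiperazin-1-yl)propyl on the same oxygen of compound 3 would give a similar step.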